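A few compounds are considered here, and "the series" means these few. Any claim that something is new, unique, unknown or untested is made for them only; others in the source may bear on it.

Four compounds share a fused two-ring core that carries two chloro groups in one pair and a chloro plus an amino group in the other pair; each core is attached through a single carbon to a benzene ring that bears a chloromethyl arm.

Compound 1 `ClCc1ccccc1Cn1cnc2c(Cl)nc(Cl)nc21` and compound 2 `ClCc1cccc(Cn2cnc3c(Cl)nc(Cl)nc32)c1` have the same atoms joined differently; the difference between these two cores is not broken down here. Compound 3 `Nc1nc(Cl)c2ncn(Cc3ccccc3CCl)c2n1` is compound 1 with one change: amino in place of chloro on an aromatic carbon. Compound 4 `Nc1nc(Cl)c2ncn(Cc3cccc(CCl)c3)c2n1` is compound 2 with the same change: amino in place of chloro on an aromatic carbon.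

In a functional assay on ACHN cells (Homo sapiens) for cytotoxicity, read by sulforhodamine B assay, with a stated time of 48 h (a lower number here means a stronger inhibitor of growth, a higher number a weaker inhibitor of growth), compound 1 gives 470 nM. Compound 2 gives 1900 nM, and compound 3 gives 5750 nM. Among the compounds with values here, the one measured step for the chloro-to-amino change is a 12-fold higher number from compound 1 to compound 3 (1.09 log units; beyond the scatter), so that change weakened growth inhibition clearly.

Compound 4 has not yet been tested in this assay. The place of the change around the core is described in the same words for both pairs, so the change is expected to act similarly, and the step from compound 2 to compound 4 is estimated at an 11-fold higher number from compound 2 to compound 4 (1.02 log units; beyond the scatter), resting on the step measured from compound 1 to compound 3. Compound 4 is therefore expected to give about 20000 nM, with a range from 7000 nM to 55000 nM. Within the data shown here, only one earlier example of this change exists, so the estimate is uncertain.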

Compound 4, concentration for 50% growth inhibition: 2880 nM
Estimate against measurement, compound 4: 6.9-fold (0.84 log units) above; measured number below the stated range.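

In this assay, the chloro-to-amino change gives a 1.5-fold higher number from compound 2 to compound 4 (0.18 log units; within the scatter), so on this core the step cannot be told apart from the ordinary scatter of repeated measurements. Set beside the earlier step, the same change clearly does not carry over in size from one core to the other: the same change on two cores in this assay, a 12-fold higher number (1.09 log units; beyond the scatter) from compound 1 to compound 3 and a 1.5-fold higher number (0.18 log units; within the scatter) from compound 2 to compound 4, 8.1-fold (0.91 log units) apart, beyond the scatter of two such steps

These two pairs show that a step measured on one core of this series cannot simply be transferred to the other, but they do not show what makes the two cores respond differently or how the change would behave on any further core.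

From the compounds shown here alone, whether a methylamino or a methoxy group at this same place would follow the large step seen on one core or the small step seen on the other remains open. It is also open how growth inhibition would respond if the chloromethyl arm gave way to a hydroxymethyl or a plain methyl group, since every compound shown carries that arm.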